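This account rests on a few compounds, and the source may have more. Where it says the series, first, only, none or still open, it means among the compounds named here.

Measured compounds in the series:
- compound 1, `CCCn1c(=O)[nH]c2nc(-c3ccc(S(=O)(=O)N4CCN(c5cccc(Br)c5)CC4)cc3)[nH]c2c1=O`: 0.234 nM
- compound 2, `CCCn1c(=O)[nH]c2nc(-c3ccc(S(=O)(=O)N4CCN(c5ccccc5Cl)CC4)cc3)[nH]c2c1=O`: 0.403 nM
- compound 3, `CCCn1c(=O)[nH]c2nc(-c3ccc(S(=O)(=O)N4CCN(c5ccc(I)cc5)CC4)cc3)[nH]c2c1=O`: 0.159 nM

All three were run in an assay on CHO cells for displacement of a labelled ligand from adenosine receptor A2b (Homo sapiens), read by scintillation counting, with a stated time of 75 min, in the presence of a further agent that is not named here; a higher number here means a weaker inhibitor, a lower number a stronger inhibitor. Compound 1 sits second highest of the three numbers; the nearest is compound 3, the furthest compound 2. The step of a 1.5-fold lower number from compound 1 to compound 3 (0.17 log units; within the scatter) and the step of a 1.7-fold higher number from compound 1 to compound 2 (0.24 log units; within the scatter) both stay within the scatter, so the three halogenated phenyl groups on the amine nitrogen in the ring cannot be ordered against one another from these data. Among the compounds with values here, only the step of a 2.5-fold lower number from compound 2 to compound 3 (0.40 log units; beyond the scatter) goes modestly beyond it.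

Compound 4, `CCCn1c(=O)[nH]c2nc(-c3ccc(S(=O)(=O)N4CCN(Cc5ccc(Br)c(F)c5)CC4)cc3)[nH]c2c1=O`, has not yet been measured. Its change from compound 1 is 4-bromo-3-fluorobenzyl in place of 3-bromophenyl on an amine nitrogen in a ring. Within the data shown here, no measured pair covers this kind of change: the three measured steps only swap one halogenated phenyl for another, and none inserts the extra carbon of a benzyl group or adds fluorine. Among the measured compounds shown here, those steps show that such aryl swaps barely move this assay, which is the only guide available, so the step of a 2.1-fold higher number from compound 1 to compound 4 (0.33 log units; beyond the scatter) is expected to be small, with a wider range than usual to allow for the benzyl insertion. Compound 4 is estimated at 0.5 nM, between 0.15 nM and 2 nM.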

Compound 4, inhibition constant: 0.473 nM
Estimate against measurement, compound 4: 1.1-fold (0.02 log units) above, within the range that was stated.
By their numbers in this assay, from the lowest: compounds 3, 1, 2 and 4 (each within the scatter of the next, the first and the last beyond it).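

Within the data shown here, the 4-bromo-3-fluorobenzyl group is the first group at this amine nitrogen in a ring that is not a halogenated phenyl, and in this assay compound 4 still gives 0.473 nM, so this position accepts a benzyl group with only a modest shift: a 2.0-fold higher number from compound 1 to compound 4 (0.31 log units; beyond the scatter) and a 3.0-fold higher number from compound 3 to compound 4 (0.47 log units; beyond the scatter) both go beyond the scatter, the second being the larger. Against the 2-chlorophenyl group the change does not separate the compounds, with a 1.2-fold higher number from compound 2 to compound 4 (0.07 log units; within the scatter) staying within the scatter, so the benzyl group sets compound 4 apart from some of the halogenated phenyl compounds but not from all of them. No measurement is available that would explain these shifts.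

The change brings in the extra benzyl carbon and the fluorine together, so their separate contributions stay unresolved; a 3-bromobenzyl or 4-bromobenzyl group at this position would bear on that. Also open, on these data alone, is how this assay reads a group of another kind on the same nitrogen, such as a phenylethyl chain, a methoxy-substituted phenyl or a carboxylic acid on the aromatic ring.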